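Cyclopentyloxy to 4-chlorophenoxy on an acylguanidine core

The compounds below may be only part of what the source reports. "The series", "measured", "known", "first", "only" and "open" are said of these compounds alone.

Compound 1 `Cc1cc(C2CCC2)c(S(C)(=O)=O)cc1C(=O)N=C(N)N` gives 8.2 nM in a functional assay for inhibition of sodium/hydrogen exchanger (Oryctolagus cuniculus); a higher number here means a weaker inhibitor, a lower number a stronger inhibitor.
Compound 2 `Cc1cc(Sc2cccc(Cl)c2)c(S(C)(=O)=O)cc1C(=O)N=C(N)N` gives 37 nM in this assay.
Compound 3 `Cc1cc(OC2CCCC2)c(S(C)(=O)=O)cc1C(=O)N=C(N)N` gives 27 nM in this assay.

Among the three measured compounds, compound 3 stands second highest, within the scatter of compound 2 and beyond it relative to compound 1. Compound 4 `Cc1cc(Oc2ccc(Cl)cc2)c(S(C)(=O)=O)cc1C(=O)N=C(N)N` carries 4-chlorophenyl in place of cyclopentyl on an oxygen on an aromatic ring. Within the data shown here, two measured steps bear on this change. Replacing cyclobutyl by a ring-bearing group gave a 4.5-fold higher number from compound 1 to compound 2 (0.65 log units; beyond the scatter) and a 3.3-fold higher number from compound 1 to compound 3 (0.52 log units; beyond the scatter), and the aryl-sulfanyl and cycloalkyloxy compounds sit close together, as a 1.4-fold lower number from compound 2 to compound 3 (0.14 log units; within the scatter) shows. Among the measured compounds shown here, an aryl group on oxygen has no direct precedent here, but the closeness of compound 2 to compound 3 suggests that swapping a cycloalkyl for a chlorinated aryl ring on the linking atom is expected to move this assay little, at most modestly toward a higher number. Compound 4 is therefore estimated at 35 nM, with a range of 12 nM to 100 nM, which is expected to mean a 1.3-fold higher number from compound 3 to compound 4 (0.11 log units; within the scatter).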

Compound 4, half-maximal inhibitory concentration: 13 nM
Estimate against measurement, compound 4: 2.7-fold (0.43 log units) above; low and high end bracket the measured number.
By their numbers in this assay, from the lowest: compounds 1 and 4 (each within the scatter of the next); then compounds 3 and 2 (each within the scatter of the next).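

On the oxygen on an aromatic ring, 4-chlorophenyl outperforms cyclopentyl in this assay (a 2.1-fold lower number from compound 3 to compound 4 (0.32 log units; beyond the scatter)) and so shows that the closeness of the aryl-sulfanyl and cycloalkyloxy compounds does not extend to this aryl ether. The 4-chlorophenoxy group also improves on (3-chlorophenyl)sulfanyl (a 2.8-fold lower number from compound 2 to compound 4 (0.45 log units; beyond the scatter)) and, unlike the other two replacements, stays within the scatter of cyclobutyl (a 1.6-fold higher number from compound 1 to compound 4 (0.20 log units; within the scatter)). Nothing available here accounts for these differences.

The step from (3-chlorophenyl)sulfanyl to 4-chlorophenoxy changes the linking atom and the place of the chlorine together, so the compounds shown cannot separate the two changes. Going by these compounds, whether unsubstituted phenoxy, or a phenoxy ring carrying an amine or a carboxylic acid, would keep this level in this assay remains open.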